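The source may report more compounds than this note shows. Statements on the series, on what has been measured and on what is new or still open speak of the compounds shown alone.

Working notes on the benzimidazole-free description: the shared core carries a para-linked aryl ether, and the series varies only the amine-bearing group on that oxygen. Within the data shown here, compound 1 `NC(=O)c1ccc2[nH]c(-c3ccc(OC4CCCNC4)cc3)nc2c1` is the first member. In a physicochemical assay for solubility, with a stated time of 3 days, at pH 2 (a higher number here means a more soluble compound, a lower number a less soluble compound), compound 1 returns a limit rather than a number, namely > 400000 nM. Compound 2 `NC(=O)c1ccc2[nH]c(-c3ccc(OC4CCNCC4)cc3)nc2c1` is the piperidin-4-yl ether. For compound 2 in this assay the outcome is "not determined" (no result reported), so compound 2 stands without a number of its own. Among the measured compounds shown here, the only value shown for the pair belongs to compound 1 and is a limit, as noted in the limit of > 400000 nM in this assay, at which 1 of the 2 values shown sits.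

Compound 3 `NC(=O)c1ccc2[nH]c(-c3ccc(OCC4CCNCC4)cc3)nc2c1` differs from compound 2 by (piperidin-4-yl)methyl in place of piperidin-4-yl on an oxygen on an aromatic ring. For the measured compounds named here, no measured step between these two exists, and in this assay no change beyond the scatter is expected from placing (piperidin-4-yl)methyl in place of piperidin-4-yl on the aryl oxygen. Compound 3 is expected to give roughly 400000 nM, within a range of 150000 nM to 1000000 nM, most likely again reported as a limit.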

Compound 3, solubility: > 400000 nM
Compound 3: a limit, no number (the forecaster's own chance of this, stated with the estimate: 70%); the middle value lies on the limit itself.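

Compound 1 and compound 3 each return only a limit in this assay, and no step from one to the other can be read: the limit of > 400000 nM in this assay, at which 2 of the 3 values shown sit.

The compounds shown leave open whether the groups on the oxygen differ at all in solubility, with no compound here carrying a number of its own.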